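Exchanging the fluorophenyl amide for an imidazole amide

The source may hold more compounds than are shown below. What is called first, only, known or untested is meant among the compounds shown, and "the series" means these compounds.

Compound 1, `COc1ccccc1-c1cnc(NC(=O)c2ccc(F)cc2)n1C`, carries the shared core with a 2-methoxyphenyl group and a 4-fluorophenyl amide. In a toxicity assay on THP-1 cells (Homo sapiens) for inhibition (a lower number here means that less compound is tolerated, a higher number that more compound is tolerated), compound 1 reaches only the limit of the measurement, > 100000 nM. Compound 2, `Cc1ccccc1-c1cnc(NC(=O)c2ccc(F)cc2)n1C`, is likewise known only as a limit in this assay, > 50000 nM. Compound 3, `COc1cccc(-c2cnc(NC(=O)c3ccc(F)cc3)n2C)c1`, again returns a limit in this assay, > 100000 nM. The three steps among these compounds, a step that the two limits leave unreadable from compound 1 to compound 2, a step that the two limits leave unreadable from compound 1 to compound 3 and a step that the two limits leave unreadable from compound 2 to compound 3, cannot be sized, since each end sits at a limit; the evidence is summarised by the limit of > 100000 nM in this assay, at which 2 of the 3 values shown sit, and (the limit of > 50000 nM in this assay, at which 1 of the 3 values shown sits).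

Compound 4, `COc1ccccc1-c1cnc(NC(=O)c2ncc[nH]2)n1C`, differs from compound 1 as follows: 1H-imidazol-2-yl in place of 4-fluorophenyl on a carbonyl carbon. Among the compounds with values here, none of the measured steps touches the amide side of the core, so no step bears directly on this change. Within the data shown here, what the measured compounds do show is that every variation so far has left the tolerated concentration at the limit of this assay. On that basis the step from compound 1 to compound 4 is expected to stay within the scatter, a number no higher from compound 1 to compound 4 (the limit leaves the size open). Compound 4 is therefore estimated to give about 100000 nM in this assay, most likely again reported as a limit, with a range from 30000 nM to 300000 nM.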

Compound 4, half-maximal cytotoxic concentration: > 50000 nM
Compound 4 gave a limit, no number; the forecaster's own chance of this, stated with the estimate: 75%; the middle value is on the limit's open side.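

In this assay compound 4 returns only a limit, > 50000 nM. Compound 1 is likewise known only as a limit, so the step between compound 1 and compound 4 cannot be read. The compounds shown leave open what concentration any of them actually tolerates, and whether 1H-imidazol-2-yl in place of 4-fluorophenyl changes it.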